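The source may report more compounds than this note shows. Statements on the series, on what has been measured and on what is new or still open speak of the compounds shown alone.

Of the compounds shown here, three have so far been measured in an in vitro functional assay on RBL cells for antagonist activity at C-C chemokine receptor type 8 (Homo sapiens), read by FLIPR and calcium flux; a higher number here means a weaker inhibitor, a lower number a stronger inhibitor: compound 1 `COc1ccc2nccc(C3CN(C4CCCCN(Cc5cc6ccccc6[nH]5)C4)C(=O)O3)c2c1`, compound 2 `O=C1OC(c2cccc3ccccc23)CN1C1CCN(Cc2cc3ccccc3[nH]2)CC1` and compound 3 `COc1ccc2nccc(C3CN(C4CCN(Cc5c[nH]c6ccccc56)CC4)C(=O)O3)c2c1`. For compound 1 the result is only a limit of the assay, < 50200 nM. For compound 2 the result is likewise a limit of the assay, < 50200 nM. For compound 3 the result is again a limit of the assay, < 50200 nM. Going by the values given here, compound 3 thus stands exactly where the other two stand, all three sitting at the limit of < 50200 nM in this assay, at which 3 of the 3 values shown sit, and no number separates them, so no step between measured compounds is known.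

Compound 4 `CCCCCCN1CCC(N2CC(c3ccnc4ccc(OC)cc34)OC2=O)CC1` has not yet been measured. It differs from compound 3 in one place: pentyl in place of 1H-indol-3-yl on a saturated chain carbon bound to an amine nitrogen in a ring. Among the compounds with values here, with no measured step to set the size of such a change, the expectation rests on the shared limit alone. The step from compound 3 to compound 4 is expected to be small, a step that the limit leaves unreadable from compound 3 to compound 4, not clearly beyond the usual scatter in either direction. For compound 4 in this assay the estimated value is 10000 nM, with a range from 2000 nM to 50000 nM.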

Compound 4, half-maximal inhibitory concentration: 501 nM
For compound 4 the middle estimate is 20-fold (1.30 log units) above the measured one; measured number outside the range, below it.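

No size can be read for the change from compound 3 to compound 4, since the result for compound 3 is only a limit of the assay: the limit of < 50200 nM in this assay, at which 3 of the 4 values shown sit. The compounds shown leave open how far compound 3 truly stands from compound 4 in this assay and whether swapping (1H-indol-3-yl)methyl for hexyl matters.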